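The source may report more compounds than this note shows. Statements on the series, on what has been measured and on what is new or still open speak of the compounds shown alone.

Measured compounds in a functional assay on the whole organism (blood) with Rattus norvegicus as the target, with stated times of 24 h and 1 h, at a dose of 15 mg/kg by the intraperitoneal route; a higher number here means a stronger effect of the compound at the dose given, a lower number a weaker effect:

Compound 1 `Cc1ncsc1C(=O)NCCC1CCN(S(=O)(=O)NC(=O)NC[C@@H]2C[C@@H]3C=C[C@@H]2C3)CC1` gives 25%.
Compound 2 `O=C(NC[C@@H]1C[C@@H]2C=C[C@@H]1C2)NS(=O)(=O)N1CCC(CCNC(=O)c2cscn2)CC1` gives 37%.
Compound 3 `CSc1ccc(C(F)(F)F)cc1C(=O)NCCC1CCN(S(=O)(=O)NC(=O)NC2CCCCC2)CC1` gives 24%.

Compound 2 stands highest of the three numbers in this assay; the nearest is compound 1, and compound 3 lies a little further down. Both gaps are beyond the scatter.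

The next compound to be measured is compound 4 `Cn1cccc(C(=O)NCCC2CCN(S(=O)(=O)NC(=O)NC[C@@H]3C[C@@H]4C=C[C@@H]3C4)CC2)c1=O`. It differs from compound 2 as follows: a group of 8 heavy atoms (6 carbon, 1 nitrogen, 1 oxygen; one six-membered aromatic ring with 1 hetero atom) in place of a group of 5 heavy atoms (3 carbon, 1 nitrogen, 1 sulfur; one five-membered aromatic ring with 2 hetero atoms), on a carbonyl carbon. The entering group is larger than the leaving one and carries one double bond outside the aromatic ring, while the count of hydrogen-bond donors and acceptors is unchanged.

Within the data shown here, only one measured step touches the same position, the exchange of one five-membered aromatic ring for another on the carbonyl carbon: a number 12 percentage points higher from compound 1 to compound 2 (beyond the scatter). That step did not involve a six-membered ring, so it bears on compound 4 only loosely, showing that the group on this carbonyl carbon can shift the read-out by a modest amount in either direction. Compound 3, with a different group at the same place, sits near compound 1. On that basis the expected step of a number 8 percentage points lower from compound 2 to compound 4 (within the scatter) is small, most likely downward but not beyond the scatter. For compound 4 the estimate in this assay is 29%, with a range from 14% to 44%.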

Compound 4, a percentage reported as activity, at one dose (the size of the read-out at that dose, not a potency): 40%
The estimate for compound 4 lay 11 percentage points below the measured number, within the range that was stated.
By their numbers in this assay, from the lowest: compounds 3 and 1 (each within the scatter of the next); then compounds 2 and 4 (each within the scatter of the next).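

In this assay the exchange on the carbonyl carbon of a five-membered aromatic ring for a larger six-membered aromatic ring with 1 hetero atom gives a number 3 percentage points higher from compound 2 to compound 4 (within the scatter) and so leaves the read-out unresolved from that of 1,3-thiazol-4-yl. The same six-membered group set against 4-methyl-1,3-thiazol-5-yl gives a number 15 percentage points higher from compound 1 to compound 4 (beyond the scatter) and shows that a read-out at the level of compound 2 is not confined to a single ring type or ring size at this position. Among the three compounds that differ only on this carbonyl carbon, compound 1 is now the one that separates from the others, while the groups of compound 2 and compound 4 cannot be told apart, and nothing available gives a reason for these steps.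

A phenyl ring, a saturated ring such as cyclohexyl, or a group carrying an amine or a carboxylic acid on this carbonyl carbon would show whether an aromatic ring with hetero atoms is needed here at all. From the compounds shown here alone, the read-out in this assay also comes from one dose, so whether compound 2 and compound 4 would still match at other doses remains open.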